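Working notes: from compound 3 to compound 4

This account rests on a few compounds, and the source may have more. Where it says the series, first, only, none or still open, it means among the compounds named here.

Measured so far:
Compound 1 `NCCSCCc1c[nH]c2ccc(F)cc12` gives, in an assay on isolated protein (urine) for inhibition of Myeloperoxidase (Homo sapiens), with a stated time of 5 min (on this read-out higher numbers stand for weaker inhibition and lower numbers for stronger inhibition), compound 1 a value of 4 nM.
Compound 2 `NCCSCCCc1c[nH]c2c(F)cccc12` is reported in this assay only as a limit, compound 2 sitting at > 100 nM.
Compound 3 `CCSCCc1c[nH]c2ccc(F)cc12` is likewise reported in this assay only as a limit, compound 3 sitting at > 100 nM.

Compound 3 therefore stands at the upper edge of what the numbers show: it has no number of its own, only (the limit of > 100 nM in this assay, at which 2 of the 3 values shown sit). Within the data shown here, the one measured step that reaches it is an at least 25-fold higher number from compound 1 to compound 3 (1.39 log units; beyond the scatter), a large loss, and it is the only single-point change on record. Compound 1 and compound 2 differ in more than one place, so their values are only read side by side: compound 1 carries a number, compound 2 a limit.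

Compound 4 `CCCc1c[nH]c2ccc(F)cc12` is the next cut: methyl in place of ethylsulfanyl on a saturated chain carbon, two bonds along the chain from an aromatic carbon. Among the measured compounds shown here, no measured step removes the ethylsulfanyl, so nothing here tells how large its removal is. Since compound 3 already sits at the limit, a further change is expected to leave compound 4 at or past that limit, and the step that the limit leaves unreadable from compound 3 to compound 4 is estimated as no measurable gain. For compound 4 the estimate is 400 nM, within the range 100 nM to 5000 nM.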

Compound 4, half-maximal inhibitory concentration: > 100 nM
Compound 4: only a limit was reported; the forecaster's own chance of this, stated with the estimate: 85%; the middle value lies beyond the limit too.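

Compound 4 is reported in this assay only as a limit, > 100 nM, and it joins the other compounds held at that limit: the limit of > 100 nM in this assay, at which 3 of the 4 values shown sit.

Replacing the whole (2-aminoethyl)sulfanyl group with methyl gives an at least 25-fold higher number from compound 1 to compound 4 (1.39 log units; beyond the scatter), so this shorter propyl chain, which carries neither sulfur nor amino group, does not restore a measurable value on the shared core. The step between the two compounds without the amino group cannot be read, since both are limits, and any contribution of the ethylsulfanyl group relative to methyl therefore stays hidden beyond the assay's limit.

The compounds shown leave open whether the sulfur matters once the terminal amine is kept, a question that an all-carbon chain ending in an amine would address directly. They also leave open whether another group at the chain end, such as a hydroxyl or a carboxylic acid, could stand in for the amine, and how far a chain that keeps the amine can change in length on this fluorinated core.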